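Methyl on the Side Chain and Gastric Inhibition

A few compounds are considered here, and "the series" means these few. Any claim that something is new, unique, unknown or untested is made for them only; others in the source may bear on it.

Three compounds measured in a functional assay on the whole organism (stomach) for inhibition, with Rattus norvegicus as the target, at a dose of 100 mg/kg by the intraduodenal route (on this read-out lower numbers stand for less inhibition and higher numbers for more inhibition at the one dose given (going by the name of the read-out)), share the same kind of side chain ending in a thioamide-like group carried on a ring nitrogen. Compound 3 `CC1=NN(CCC(=N)S)C(=O)CC1` gives 34.8%. Compound 1 `CC1=NN(CC(C)C(=N)S)C(=O)CC1` carries one more carbon on that chain; in this assay compound 1 gives 15.6%. The step between them, a number 19.2 percentage points lower from compound 3 to compound 1 (beyond the scatter), comes from the change (methyl in place of hydrogen on a saturated chain carbon bound to a carbon with a double bond to nitrogen and a saturated chain carbon). Compound 2 `C/N=C(\S)CCn1ncccc1=O` rests on a different core; the difference between the two cores is not broken down here. In this assay compound 2 gives 35.7%, which lies within the scatter of the value of compound 3, so no order between the two can be claimed. Compound 4 `C/N=C(\S)CC(C)n1ncccc1=O` is not yet measured. It arises from compound 2 through (methyl in place of hydrogen on a saturated chain carbon bound to an aromatic nitrogen and a saturated chain carbon), the same kind of change as that from compound 3 to compound 1, though the place is not the same: in compound 4 the carbon carrying the methyl is bound to an aromatic nitrogen, whereas in compound 1 it is bound to a carbon with a double bond to nitrogen. Going by the values given here, because the one measured step of this kind, a number 19.2 percentage points lower from compound 3 to compound 1 (beyond the scatter), is a modest drop beyond the scatter, a similar fall is expected for compound 4, giving an estimated a number 17.7 percentage points lower from compound 2 to compound 4 (beyond the scatter). The inhibition of compound 4 in this assay is therefore expected to be about 18%, with a likely range from 5% to 32%.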

Compound 4, a percentage reported as inhibition, in the whole organism at one dose (the size of the read-out at that dose, not a potency): 42.7%
The estimate for compound 4 lay 24.7 percentage points below the measured number, outside the stated range (above it).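

On the core of compound 2, in this assay, methyl in place of hydrogen on a saturated chain carbon bound to an aromatic nitrogen and a saturated chain carbon gives a number 7 percentage points higher from compound 2 to compound 4 (within the scatter), so this step shows neither a gain nor a loss of inhibition. The drop seen on the other core therefore did not carry over to this one, and the two steps differ by more than their scatter: the same change on two cores in this assay, a number 19.2 percentage points lower (beyond the scatter) from compound 3 to compound 1 and a number 7 percentage points higher (within the scatter) from compound 2 to compound 4, 26.2 percentage points apart, beyond the scatter of two such steps. This does not show whether the core or the place of the methyl sets the two steps apart, since the carbon carrying the methyl is bound to an aromatic nitrogen in compound 4 and to a carbon with a double bond to nitrogen in compound 1, and two steps at a single dose give no general rule for the series.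

The compounds shown leave open whether a methyl on each core at the place it holds on the other would separate the effect of the core from that of the place. They also leave open whether an ethyl group or a longer chain on the same saturated chain carbon would follow either step.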